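A few compounds are considered here, and "the series" means these few. Any claim that something is new, unique, unknown or untested is made for them only; others in the source may bear on it.

Measured compounds in this series:
- compound 1 `Cc1c(Cc2c(F)cccc2F)nc(N(C)C(C)C)[nH]c1=O`: 79000 nM
- compound 2 `CCCN(C)c1nc(Cc2c(F)cccc2F)c(C)c(=O)[nH]1`: > 81000 nM, a limit of the assay
- compound 3 `Cc1c(C(C)c2c(F)cccc2F)nc(N(C)C(C)C)[nH]c1=O`: > 81000 nM, a limit of the assay

In an ADME assay on MT4 cells (Homo sapiens) for cytotoxicity, read by MTT assay, with a stated time of 4 days (on this read-out higher numbers stand for lower toxicity in this test and lower numbers for higher toxicity in this test), compound 1 gives 79000 nM. For compound 2 the value > 81000 nM is a limit, not a number. For compound 3 the value > 81000 nM is likewise a limit. The change propyl in place of isopropyl on a nitrogen on an aromatic ring gives an at least 1.0-fold higher number from compound 1 to compound 2 (0.01 log units; that floor lies within the scatter). The change (methyl in place of hydrogen on a saturated chain carbon bound to two aromatic carbons), which is also how the core of compound 3 differs from the core of compound 1, gives an at least 1.0-fold higher number from compound 1 to compound 3 (0.01 log units; that floor lies within the scatter). Both floors sit at the limit of > 81000 nM in this assay, at which 2 of the 3 values shown sit.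

Compound 4 `CCCN(C)c1nc(C(C)c2c(F)cccc2F)c(C)c(=O)[nH]1` is not yet measured. It differs from compound 3 by propyl in place of isopropyl on a nitrogen on an aromatic ring, the same change as from compound 1 to compound 2. In this assay the step from compound 3 to compound 4 is expected to be a step that the limit leaves unreadable from compound 3 to compound 4, resting on compound 3 already standing at a limit, > 81000 nM, and on the step of an at least 1.0-fold higher number from compound 1 to compound 2 (0.01 log units; that floor lies within the scatter). Compound 4 is therefore estimated at 100000 nM, most likely again reported only as a limit.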

Compound 4, half-maximal cytotoxic concentration: > 78000 nM
Compound 4 gave a limit, no number (the forecaster's own chance of this, stated with the estimate: 80%); the middle value is on the limit's open side.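

In this assay compound 4 gives > 78000 nM as a limit, so the steps to it from compound 2 and compound 3 cannot be read. The compounds shown leave open whether either change, alone or combined, moves this read-out at all.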